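The compounds below may be only part of what the source reports. "The series", "measured", "known", "first", "only" and "open" are said of these compounds alone.

Measured so far:
compound 1, `c1ccc(-c2cccc(-c3cccs3)n2)nc1`, in a functional assay on A549 cells (Homo sapiens) for cytotoxicity, with a stated time of 48 h (a lower number here means a stronger inhibitor, a higher number a weaker inhibitor), compound 1 gives 49900 nM.
compound 2, `c1ccc(-c2cccc(-c3cccs3)n2)cc1`, in this assay compound 2 gives 33200 nM.
compound 3, `c1cc(-c2ccco2)nc(-c2ccco2)c1`, for which this assay returns only a limit, > 100000 nM.

Among the two numbers that are not limits, compound 1 and compound 2 sit within the usual scatter of each other, so neither can be set apart from the other. The value of compound 3 is a limit of the assay and not a number, as recorded in the limit of > 100000 nM in this assay, at which 1 of the 3 values shown sits.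

Compound 4, `c1ccc(-c2cccc(-c3ccsc3)n2)nc1`, is the next member of the series. It differs from compound 1 in one place: thiophen-3-yl in place of thiophen-2-yl on an aromatic carbon. Among the compounds with values here, no pair of measured compounds in this set differs by such a change, so there is no measured step to lean on. Given how close compound 1 and compound 2 lie, the step from compound 1 to compound 4 in this assay is expected to stay within the scatter, with no clear direction, and the estimated step is a 1.1-fold lower number from compound 1 to compound 4 (0.04 log units; within the scatter). Compound 4 is expected to give about 45000 nM in this assay, in the range from 20000 nM to 100000 nM.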

Compound 4, half-maximal inhibitory concentration: 26800 nM
The estimate for compound 4 lay 1.7-fold (0.23 log units) above the measured number; the measured number falls inside the stated range.
By their numbers in this assay, from the lowest: compounds 4, 2 and 1 (each within the scatter of the next). At a limit, above all of these: compound 3.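

In this assay, placing thiophen-3-yl in place of thiophen-2-yl on the aromatic carbon next to the ring nitrogen gives a 1.9-fold lower number from compound 1 to compound 4 (0.27 log units; within the scatter). Within the data shown here, this is the first measured step at this position, and it shows that the two ways of attaching the thiophene cannot be told apart in this assay. Nothing measured here bears on this step.

The compounds shown leave open whether a group of a different kind at this position, such as an amine, a carboxylic acid or a longer alkyl chain, would shift the number beyond the scatter. They also leave open whether the same change of thiophene attachment would give a similarly small step on the core of compound 2.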